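This account rests on a few compounds, and the source may have more. Where it says the series, first, only, none or still open, it means among the compounds named here.

Measured so far in a functional assay on MCF7 cells (Homo sapiens); a lower number here means a stronger inhibitor of growth, a higher number a weaker inhibitor of growth:
compound 1, `O=S(=O)(/C=C/c1ccc(Cl)c(Cl)c1)Cc1ccc(Nc2ncnc3ccccc23)cc1`, 28000 nM
compound 2, `O=S(=O)(/C=C/c1ccc(Cl)cc1)Cc1ccc(Nc2ncnc3ccccc23)cc1`, 52000 nM
compound 3, `O=S(=O)(/C=C/c1ccc(F)cc1F)Cc1ccc(Nc2ncnc3ccccc23)cc1`, > 100000 nM, which is a limit of the assay and not a number.

Compound 3 therefore stands at the limit of > 100000 nM in this assay, at which 1 of the 3 values shown sits. Compound 4, `O=S(=O)(/C=C/c1ccc(O)cc1)Cc1ccc(Nc2ncnc3ccccc23)cc1`, differs from compound 3 in one place: 4-hydroxyphenyl in place of 2,4-difluorophenyl on a double-bonded chain carbon bound to a double-bonded chain carbon. Among the measured compounds shown here, two measured steps touch the same place of the shared core. an at least 3.5-fold higher number from compound 1 to compound 3 (0.55 log units; beyond the scatter), and an at least 1.9-fold higher number from compound 2 to compound 3 (0.28 log units; that floor lies within the scatter). Both steps ran toward compound 3 and both read as weaker growth inhibition there, while a 4-hydroxyphenyl at this place has no measured parallel among these compounds. Compound 4 is expected to remain in the weak range, with a step of about an at least 1.4-fold lower number from compound 3 to compound 4 (0.15 log units; that floor lies within the scatter). Compound 4 is estimated at 70000 nM, from 25000 nM to 200000 nM.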

Compound 4, concentration for 50% growth inhibition: 100000 nM
Beside the measured number, compound 4's estimate is 1.4-fold (0.15 log units) below it, within the range that was stated.
By their numbers in this assay, from the lowest: compounds 1, 2 and 4 (each within the scatter of the next, the first and the last beyond it).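

In this assay, the number with hydroxy cannot be told apart from that of the chloro compound: a 1.9-fold higher number from compound 2 to compound 4 (0.28 log units; within the scatter). Against the 3,4-dichlorophenyl group, the 4-hydroxyphenyl group reads as weaker growth inhibition, a 3.6-fold higher number from compound 1 to compound 4 (0.55 log units; beyond the scatter), so a hydrogen-bond donor at this place brings no gain over that group. The remaining step is a number no higher from compound 3 to compound 4 (the limit leaves the size open), and its size cannot be read. That is because compound 3 stands at a limit of the assay: the limit of > 100000 nM in this assay, at which 1 of the 4 values shown sits.

Still open, from the compounds shown here alone, is how a methoxy group, an amine or a carboxylic acid on this ring would compare with hydroxy.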